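The compounds below may be only part of what the source reports. "The series", "measured", "known", "first", "only" and "open" are said of these compounds alone.

In a functional assay on A20 cells (Mus musculus) for inhibition, with stated times of 1 h, 16 h and 24 h (a higher number here means a weaker inhibitor, a lower number a stronger inhibitor), three compounds sharing a core have been measured: compound 1 `N#CC1(NC(=O)[C@@H]2C[C@@H](S(=O)(=O)c3ccccc3)C[C@H]2C(=O)N2CC3(COC3)C2)CC1` gives 248 nM, compound 2 `CC1CCN(C(=O)[C@@H]2C[C@H](S(=O)(=O)c3ccccc3)C[C@H]2C(=O)NC2(C#N)CC2)CC1` gives 2 nM, and compound 3 `CN1CCN(C(=O)[C@@H]2C[C@H](S(=O)(=O)c3ccccc3)C[C@H]2C(=O)NC2(C#N)CC2)CC1` gives 17 nM, the second highest of the three numbers. Compound 4 `N#CC1(NC(=O)[C@@H]2C[C@@H](S(=O)(=O)c3ccccc3)C[C@H]2C(=O)N2CCNCC2)CC1` departs from compound 3 by hydrogen in place of methyl on an amine nitrogen in a ring. For the measured compounds named here, no measured step makes this exact change. The closest is the modest 8.5-fold higher number from compound 2 to compound 3 (0.93 log units; beyond the scatter), which also alters the group on the carbonyl carbon, whereas the large 120-fold lower number from compound 1 to compound 2 (2.09 log units; beyond the scatter) and a 15-fold lower number from compound 1 to compound 3 (1.16 log units; beyond the scatter) replace that group entirely. A small move to a higher number is therefore expected, a 2.4-fold higher number from compound 3 to compound 4 (0.37 log units; beyond the scatter). Compound 4 is estimated at 40 nM, with an expected range of 12 nM to 130 nM.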

Compound 4, half-maximal inhibitory concentration: 1340 nM
The estimate for compound 4 lay 34-fold (1.53 log units) below the measured number; measured number outside the range, above it.
By their numbers in this assay, from the lowest: compound 2; then compound 3; then compound 1; then compound 4.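

In this assay, for the compounds shown here, hydrogen in place of methyl on the amine nitrogen in the ring gives a 79-fold higher number from compound 3 to compound 4 (1.90 log units; beyond the scatter) and so this single methyl counts for far more than the earlier steps showed. With a 670-fold higher number from compound 2 to compound 4 (2.83 log units; beyond the scatter) and a 5.4-fold higher number from compound 1 to compound 4 (0.73 log units; beyond the scatter) compound 4 has the highest number of the four. Nothing shown here explains this loss. As far as these compounds go, whether ethyl, acetyl or a longer chain on that nitrogen would match methyl remains open, and so does whether the methyl matters equally in the 4-methylpiperidin-1-yl series.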